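The compounds below may be only part of what the source reports. "The series", "measured", "known", "first", "only" and "open" are said of these compounds alone.

Working notes on the series. In a functional assay on KYSE-70 cells for antiproliferative activity against KYSE-70 cell line (Homo sapiens), read by MTT assay, with a stated time of 72 h (a lower number here means a stronger inhibitor, a higher number a weaker inhibitor), compound 1 `O=C(c1cc(=O)[nH]c2cc(Br)ccc12)N1CCCCC1` gives > 20000 nM, which is a limit and not a number. Compound 2 `O=C(Nc1cccc(F)c1)c1cc(=O)[nH]c2cc(-c3ccccc3)ccc12` gives > 20000 nM, which is also a limit and not a number. Compound 2 therefore has no numerical position in the series, and the record so far reads (the limit of > 20000 nM in this assay, at which 2 of the 2 values shown sit).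

Compound 3 `CC(=O)c1ccc(-c2ccc3c(C(=O)Nc4cccc(F)c4)cc(=O)[nH]c3c2)cc1` takes compound 2 and replaces phenyl with 4-acetylphenyl, an acetyl in place of hydrogen on an aromatic carbon. Among the measured compounds shown here, no measured pair tests this change. In this assay no step beyond the scatter is firmly expected. A weaker compound 3 would read as the same limit, so only a move toward stronger inhibition could show. The expected step of an at least 1.1-fold lower number from compound 2 to compound 3 (0.04 log units; that floor lies within the scatter) is small. For compound 3 the estimated value is 18000 nM, with an expected range of 6000 nM to 40000 nM.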

Compound 3, half-maximal inhibitory concentration: > 20000 nM
Compound 3 ended at the assay's limit (the forecaster's own chance of this, stated with the estimate: 65%); at least 1.1-fold (0.04 log units) between middle value and limit.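

Compound 2 and compound 3 both stand at a limit, not a number, in this assay, so no step can be read between them: the limit of > 20000 nM in this assay, at which 3 of the 3 values shown sit.

The compounds shown leave open whether acetyl in place of hydrogen has any effect in this assay, and which structure would give a numerical value there.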